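Cyclopropyl for phenyl on the ring amide nitrogen

This account rests on a few compounds, and the source may have more. Where it says the series, first, only, none or still open, it means among the compounds named here.

Compound 1 `O=C1COc2ccc(-c3cccc(NS(=O)(=O)c4ccc(F)cc4)c3)cc2N1c1ccccc1` and compound 2 `O=C1COc2ccc(-c3cnc(Cl)c(NS(=O)(=O)c4ccc(F)cc4)c3)cc2N1c1ccccc1` share the sulfonamide-bearing arm but differ in the core itself; the difference between the two cores is not broken down here. In a functional assay on HepG2 cells (Homo sapiens) for antiproliferative activity, read by MTT assay, with a stated time of 72 h (on this read-out lower numbers stand for stronger inhibition and higher numbers for weaker inhibition), compound 1 gives 30300 nM and compound 2 gives 35700 nM, two numbers within the scatter of each other. Compound 3 `O=C1COc2ccc(-c3cccc(NS(=O)(=O)c4ccc(F)cc4)c3)cc2N1C1CC1` carries the change cyclopropyl in place of phenyl on an amide-type nitrogen in a ring on the core of compound 1. In this assay compound 3 reports only a limit, > 40000 nM. The step of an at least 1.3-fold higher number from compound 1 to compound 3 (0.12 log units; that floor lies within the scatter) is thus known only as a floor; the limit of > 40000 nM in this assay, at which 1 of the 3 values shown sits, marks where that value sits. Compound 4 `O=C1COc2ccc(-c3cnc(Cl)c(NS(=O)(=O)c4ccc(F)cc4)c3)cc2N1C1CC1` carries the same change, (cyclopropyl in place of phenyl on an amide-type nitrogen in a ring), on the core of compound 2; the place is described in identical words for both pairs, so it is the same change. The step from compound 2 to compound 4 is expected to be a 1.5-fold higher number from compound 2 to compound 4 (0.16 log units; within the scatter), resting on the step of an at least 1.3-fold higher number from compound 1 to compound 3 (0.12 log units; that floor lies within the scatter) seen in the first pair. Compound 4 is therefore expected at 52000 nM, most likely reported only as a limit, within 30000 nM to 95000 nM.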

Compound 4, half-maximal inhibitory concentration: 8510 nM
Estimate against measurement, compound 4: 6.1-fold (0.79 log units) above; the measured number lies below the stated range.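

In this assay, cyclopropyl in place of phenyl on an amide-type nitrogen in a ring does not carry over unchanged from one core to the other: the same change on two cores in this assay, an at least 1.3-fold higher number (0.12 log units; that floor lies within the scatter) from compound 1 to compound 3 and a 4.2-fold lower number (0.62 log units; beyond the scatter) from compound 2 to compound 4, at least 5.5-fold (0.74 log units) apart, beyond the scatter of two such steps

On the core of compound 2 the change gives a 4.2-fold lower number from compound 2 to compound 4 (0.62 log units; beyond the scatter), so the step on the core of compound 1 is no reliable guide to its size on this second core, though two pairs show no general rule and no reason for the difference. Compound 3 is known only as a limit, so the first step is a floor rather than a measured size: the limit of > 40000 nM in this assay, at which 1 of the 4 values shown sits.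

The compounds shown leave open which part of the difference between the two cores goes with the different outcome. Also open, going by these compounds, is whether the lower number of compound 4 extends to other groups on that nitrogen, such as an ethyl group or a longer chain ending in an amine.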